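Swapping one halogenated phenyl ring in an ecdysone agonist

The compounds below may be only part of what the source reports. "The series", "measured", "known", "first", "only" and "open" are said of these compounds alone.

Measured compounds:
compound 1 `COc1ccccc1C(=O)N(NC(=O)c1ccccc1)C(C)(C)C` gives 525 nM
compound 2 `Cc1cc(C)cc(C(=O)N(NC(=O)c2ccccc2)C(C)(C)C)c1` gives 69.2 nM
compound 3 `CC(C)(C)N(NC(=O)c1ccccc1Cl)C(=O)c1ccccc1Cl` gives 331 nM

These three share a core in which two aromatic rings hang from two carbonyl carbons, and were tested in an assay on cells for agonist activity at ecdysone receptor (Bombyx mori), read by a luciferase reporter, with a stated time of 24 h; on this read-out higher numbers stand for an effect only at larger amounts of compound and lower numbers for an effect already at smaller amounts. Compound 3 stands second highest of the three numbers: its nearest neighbour is compound 1, whose value is within the scatter of compound 3, while compound 2 sits clearly lower, beyond the scatter.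

Compound 4 `CC(C)(C)N(NC(=O)c1cccc(Br)c1)C(=O)c1ccccc1Cl` has not yet been measured. It differs from compound 3 in one place: 3-bromophenyl in place of 2-chlorophenyl on a carbonyl carbon.

For the measured compounds named here, only one measured step bears on this kind of change. Replacing one substituted phenyl by another on a carbonyl carbon gave a 7.6-fold lower number from compound 1 to compound 2 (0.88 log units; beyond the scatter). That exchange also removed a substituent from a 2-position ring and placed substituents elsewhere on the ring, as the change from compound 3 to compound 4 does, though the groups and the ring in question are not the same. Going by the values given here, a lowering of modest size is therefore expected, a 3.0-fold lower number from compound 3 to compound 4 (0.48 log units; beyond the scatter), with uncertainty because the one comparison available, a 7.6-fold lower number from compound 1 to compound 2 (0.88 log units; beyond the scatter), is not a direct match. Compound 4 is estimated at 110 nM, within a range from 40 nM to 330 nM.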

Compound 4, half-maximal effective concentration: 191 nM
For compound 4 the middle estimate is 1.7-fold (0.24 log units) below the measured one; measured number inside the range.
By their numbers in this assay, from the lowest: compound 2; then compounds 4, 3 and 1 (each within the scatter of the next, the first and the last beyond it).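

In this assay the exchange of 2-chlorophenyl for 3-bromophenyl on a carbonyl carbon gives a 1.7-fold lower number from compound 3 to compound 4 (0.24 log units; within the scatter) and so cannot be told apart from the ordinary spread of repeat measurements. The earlier exchange of one substituted phenyl for another, a 7.6-fold lower number from compound 1 to compound 2 (0.88 log units; beyond the scatter) on the other carbonyl carbon of the shared core, did stand clear of that spread, so a change of ring substituents does not shift the number at both carbonyl carbons in the same way in these two pairs. No independent measurement is available to explain why this exchange leaves the number within the scatter.

This single exchange alters both the halogen and its place on the ring, and the compounds shown cannot separate those two changes or show whether they offset each other. They also leave open how the number would respond if this ring carried something other than a halogen, such as an amine, a carboxylic acid or a longer carbon chain.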